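Chloro in Place of Methoxy: Expected Potency of Compound 3

The source may hold more compounds than are shown below. What is called first, only, known or untested is meant among the compounds shown, and "the series" means these compounds.

compound 1 `O=C(/C=C/c1ccccc1)NNC(=O)c1ccccc1O`: 43700 nM
compound 2 `COCOc1cc(/C=C/C(=O)OCC(=O)Nc2ccc(OC)cc2)ccc1OCc1ccccc1`: > 200000 nM

In a functional assay on CNE cells (Homo sapiens) for cytotoxicity, read by MTT assay, with a stated time of 72 h (a lower number here means a stronger inhibitor, a higher number a weaker inhibitor), compound 1 gives 43700 nM. For compound 2 this assay reports only a limit, > 200000 nM, and compound 2 thus stands at the limit of > 200000 nM in this assay, at which 1 of the 2 values shown sits. Compound 3 `COCOc1cc(/C=C/C(=O)OCC(=O)Nc2ccc(Cl)cc2)ccc1OCc1ccccc1` differs from compound 2 by chloro in place of methoxy on an aromatic carbon. Among the measured compounds shown here, no step between two measured compounds shows how this change acts in this assay, so no shift beyond the usual scatter is expected in either direction. The step of a number no higher from compound 2 to compound 3 (the limit leaves the size open) is therefore expected to be small. Compound 3 is estimated at 200000 nM, between 60000 nM and 500000 nM, and it may again be reported only as a limit.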

Compound 3, half-maximal inhibitory concentration: > 200000 nM
Compound 3 ended at the assay's limit (the forecaster's own chance of this, stated with the estimate: 65%); the middle value lies on the limit itself.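

Among the compounds shown here, compound 2 and compound 3 both end at a limit rather than a number in this assay, so no step between them can be read. The compounds shown leave open whether chloro in place of methoxy changes potency at all.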